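The source may report more compounds than this note shows. Statements on the series, on what has been measured and on what is new or still open speak of the compounds shown alone.

Compound 1, with the structure `CC(C)c1cc(Cn2ccc3cc(OCC(=O)O)ccc32)ccc1O`, compound 2, with the structure `Cc1cn(Cc2ccc(O)c(C(C)C)c2)c2ccc(OCC(=O)O)cc12`, and compound 3, with the structure `Cc1cn(Cc2ccc(O)c(C(C)C)c2)c2c(Cl)cc(OCC(=O)O)cc12`, share one core and differ only in small groups on it. In an assay on HeLa cells for displacement of a labelled ligand from thyroid hormone receptor alpha (Homo sapiens) (on this read-out lower numbers stand for stronger inhibition and higher numbers for weaker inhibition), compound 1 gives 13.5 nM, compound 2 gives 7.74 nM and compound 3 gives 0.51 nM. Compound 2 therefore stands second highest among these three numbers, separated from compound 1 by a 1.7-fold lower number from compound 1 to compound 2 (0.24 log units; within the scatter), a step too small to count, while the change to compound 3 brings a 15-fold lower number from compound 2 to compound 3 (1.18 log units; beyond the scatter), a large step.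

Compound 4, with the structure `Cc1cn(Cc2ccc(O)c(C3CCCCC3)c2)c2ccc(OCC(=O)O)cc12`, is not yet measured. It differs from compound 2 in one place: cyclohexyl in place of isopropyl on an aromatic carbon. Neither measured step touches this position. Within the data shown here, the step from compound 1 to compound 2 and the step from compound 2 to compound 3 both concern the core, not the group ortho to the hydroxy group, so no measured step bears directly on the change to compound 4. Since no evidence points in either direction, the expected step in this assay from compound 2 to compound 4 is a 1.3-fold higher number from compound 2 to compound 4 (0.11 log units; within the scatter), which stays within the scatter. Compound 4 is therefore estimated to give 10 nM in this assay, with a range from 3 nM to 35 nM.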

Compound 4, inhibition constant: 200 nM
The estimate for compound 4 lay 20-fold (1.30 log units) below the measured number, and the stated range ends below it.
By their numbers in this assay, from the lowest: compound 3; then compounds 2 and 1 (each within the scatter of the next); then compound 4.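

In this assay, the group ortho to a hydroxy group matters a great deal: cyclohexyl in place of isopropyl gives a 26-fold higher number from compound 2 to compound 4 (1.41 log units; beyond the scatter), a large step toward weaker inhibition. The earlier steps shown here all changed the core, so they gave no sign of how this position responds to a change. The two groups are alike in what can be counted for hydrogen bonding and charge, since both are carbon only, with no hydrogen-bond donors or acceptors and no net charge, but cyclohexyl has 6 heavy atoms and a ring where isopropyl has 3 heavy atoms and no ring, and nothing measured here explains the step.

With only two groups shown at this position, it remains open whether the number rises with the count of heavy atoms, with the presence of a ring, or for some other reason; an open-chain tert-butyl group or a smaller ring such as cyclopropyl would help separate these. Also open, as far as these compounds go, is whether the large effect of chloro on the core would persist with cyclohexyl in place of isopropyl.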